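The source may report more compounds than this note shows. Statements on the series, on what has been measured and on what is new or still open speak of the compounds shown alone.

Compound 1 `COc1cccc(Oc2c(NS(=O)(=O)c3ccc(C(C)(C)C)cc3)ncnc2OCCOc2ccccc2)c1` has the highest of the two numbers recorded in an assay on cells (Endothelial cell) for binding affinity to Endothelin-1 receptor (Sus scrofa); a lower number here means a stronger inhibitor, a higher number a weaker inhibitor: compound 1 gives 65 nM. Compound 2 `COc1cccc(Oc2c(NS(=O)(=O)c3ccc(C(C)(C)C)cc3)ncnc2OCCOc2ncc(C)cn2)c1` gives 0.86 nM, and the step of a 76-fold lower number from compound 1 to compound 2 (1.88 log units; beyond the scatter) shows how strongly the 5-methylpyrimidin-2-yl ring changes the number. Compound 3 `COc1cccc(Oc2c(NS(=O)(=O)c3ccc(C(C)(C)C)cc3)ncnc2OCCOc2nccc(C)n2)c1` differs from compound 1 by 4-methylpyrimidin-2-yl in place of phenyl on an oxygen on a saturated carbon, a closely related change, bringing in the same kind of ring with a methyl group. Because of the step of a 76-fold lower number from compound 1 to compound 2 (1.88 log units; beyond the scatter), a similarly large downward step is expected for compound 3, a 43-fold lower number from compound 1 to compound 3 (1.64 log units; beyond the scatter). Compound 3 is therefore estimated at 1.5 nM, within 0.4 nM to 6 nM.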

Compound 3, half-maximal inhibitory concentration: 39.4 nM
The estimate for compound 3 lay 26-fold (1.42 log units) below the measured number; measured number above the stated range.
By their numbers in this assay, from the lowest: compound 2; then compounds 3 and 1 (each within the scatter of the next).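

The place of the methyl group on the pyrimidine ring matters greatly at this position: 4-methylpyrimidin-2-yl in place of 5-methylpyrimidin-2-yl gives a 46-fold higher number from compound 2 to compound 3 (1.66 log units; beyond the scatter), so a methylpyrimidine ring as such does not secure a low number. Against phenyl, 4-methylpyrimidin-2-yl gives only a 1.6-fold lower number from compound 1 to compound 3 (0.22 log units; within the scatter), which leaves compound 3 level with compound 1. Nothing measured here explains why the place of the methyl group matters so much. Still open, on these data alone, is how a pyrimidin-2-yl ring without any methyl group would compare, or one carrying a methoxy group instead.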